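The compounds below may be only part of what the source reports. "The series", "measured", "known", "first", "only" and "open" are said of these compounds alone.

Working notes on the series. In a functional assay on the whole organism (strain Swiss) with Mus musculus as the target, in the maximal electroshock model, with a stated time of 2 h, at a dose of 100 mg/kg by the intraperitoneal route (on this read-out lower numbers stand for a weaker effect and higher numbers for a stronger effect at the one dose given), compound 1 `COCC(C(=O)N1CCN(c2cccc(C(F)(F)F)c2)CC1)N1C(=O)CCC1=O` gives 0%. Among the compounds with values here, compound 3 `CCC(C(=O)N1CCN(c2cccc(C(F)(F)F)c2)CC1)N1C(=O)CCC1=O` gives 0% in this assay, and the only single-point step among the measured compounds, no change at the digits printed from compound 1 to compound 3 (within the scatter), is a change on the saturated chain and is flat. Compound 2 `CC(C(=O)N1CCN(c2cccc(Cl)c2)CC1)N1C(=O)CCC1=O` gives 0% in this assay; it stands level with compound 1 and compound 3 at the digits shown, so no order can be drawn among the three. The next compound, compound 4 `Cc1cccc(N2CCN(C(=O)C(C)N3C(=O)CCC3=O)CC2)c1`, differs from compound 2 on the aromatic ring only: methyl in place of chloro on an aromatic carbon. Within the data shown here, no measured step changes a group on the six-membered aromatic ring of carbon only; the one measured step sits on the chain and shows no change. Compound 4 in this assay is therefore expected at 0%, with a range from 0% to 10%. The step of no change at the digits printed from compound 2 to compound 4 (within the scatter) is expected to stay within the scatter because the step of no change at the digits printed from compound 1 to compound 3 (within the scatter) did so and compound 1, compound 2 and compound 3 sit at the same level.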

Compound 4, a percentage reported as activity, at one dose (the size of the read-out at that dose, not a potency): 0%
Compound 4: middle estimate and measured number agree at the digits printed, and the stated range covers the measured number.
By their numbers in this assay, from the lowest: compounds 1, 2, 3 and 4 (each within the scatter of the next).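

In this assay, within the data shown here, the change of 3-chlorophenyl to 3-methylphenyl gives no change at the digits printed from compound 2 to compound 4 (within the scatter) and so provides the first measured step on the aromatic ring, where the earlier single step lay on the saturated chain. At this aromatic carbon, methyl in place of chloro therefore leaves the read-out unchanged at the one dose, and compound 4 gives 0% just as compound 2 gives 0% in this assay. Nothing available explains this flat result or bears on it.

Both compounds of this step show no effect, so the step cannot show whether methyl and chloro would differ in a compound with a measurable effect at this dose. It also leaves open whether an amine or a carboxylic acid on the same aromatic carbon, or a longer chain there, would lift the read-out at all.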